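A few compounds are considered here, and "the series" means these few. Any claim that something is new, unique, unknown or untested is made for them only; others in the source may bear on it.

Measured compounds:
Compound 1 `O=C(O)c1cccc(-c2c(O)ccc3cc(-c4cccc(O)c4)ccc23)c1`. In an in vitro assay on Sf9 cells for binding affinity to 17-beta-hydroxysteroid dehydrogenase type 2 (Homo sapiens), read by scintillation counting, with a stated time of 10 min, tested at 100 nM (on this read-out higher numbers stand for a stronger effect at the one concentration tested and lower numbers for a weaker effect), compound 1 gives < 10%, which is a limit of the assay and not a number.
Compound 2 `CC(=O)Nc1cccc(-c2c(O)ccc3cc(-c4cccc(O)c4)ccc23)c1`. In this assay compound 2 gives 24%.

Compound 2 holds the only number shown in this series; the other value is a limit, (the limit of < 10% in this assay, at which 1 of the 2 values shown sits). For the measured compounds named here, the one measured step, a number at least 14 percentage points higher from compound 1 to compound 2 (beyond the scatter), runs from carboxy to acetamido on an aromatic carbon and is the sole comparison available.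

Compound 3 `O=C(O)CCC(=O)Nc1cccc(-c2c(O)ccc3cc(-c4cccc(O)c4)ccc23)c1` is not yet measured. It differs from compound 2 by carboxymethyl in place of hydrogen on a saturated chain carbon bound to a carbonyl carbon. The measured step bears on it only loosely: it shows that a carboxy on the aromatic carbon sits at the limit while acetamido gives a number, and compound 3 carries a carboxy group again, now on the chain of the acetamido. A drop from compound 2 is therefore expected, but a smaller one than the measured step, since the acetamido itself stays in place.

The expected step is a number 9 percentage points lower from compound 2 to compound 3 (within the scatter). Compound 3 is estimated at 15%, within a range of 5% to 30%.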

Compound 3, a percentage reported as inhibition, at one concentration (the size of the read-out at that concentration, not a potency): 24%
Estimate against measurement, compound 3: 9 percentage points below; measured number inside the range.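

Carboxymethyl in place of hydrogen on a saturated chain carbon bound to a carbonyl carbon gives, in this assay, no change at the digits printed from compound 2 to compound 3 (within the scatter); this chain position therefore accepts a carboxy-bearing group with no loss in the read-out, which compound 2 alone could not show. Compound 1 and compound 3 both carry a carboxy group, so its presence alone does not fix the read-out in this pair, and ((2-carboxyethyl)carbonyl)amino in place of carboxy on an aromatic carbon gives a number at least 14 percentage points higher from compound 1 to compound 3 (beyond the scatter). That step starts from a limit of the assay and not from a number, so its full size stays undefined: the limit of < 10% in this assay, at which 1 of the 3 values shown sits.

Open, on these data alone, is whether the read-out holds when the chain of compound 3 is lengthened with a further methylene before the carboxylic acid, or when the acid is replaced by a methyl ester or a primary amine. Also open, as far as these compounds go, is how the effects of compound 2 and compound 3 compare at other concentrations, as the read-out gives only the size of the effect at the one concentration tested, and a stronger or weaker effect of either compound could still appear at other concentrations.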